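The source may report more compounds than this note shows. Statements on the series, on what has been measured and on what is new or still open speak of the compounds shown alone.

For the measured compounds named here, in a functional assay on DU-145 cells (Homo sapiens) for inhibition, read by trypan blue exclusion, with a stated time of 96 h (on this read-out higher numbers stand for weaker inhibition of growth and lower numbers for stronger inhibition of growth), compound 1 `O=C(/C(=C\c1ccc(F)c([N+](=O)[O-])c1)S(=O)(=O)c1ccc(Br)cc1)c1ccc(Br)cc1` gives 25000 nM and compound 2 `O=C(/C(=C\c1ccc(Br)c(O)c1)S(=O)(=O)c1ccc(Br)cc1)c1ccc(Br)cc1` gives 50000 nM, so compound 2 stands within the scatter of its only measured neighbour. Compound 3 `COc1ccc(/C=C(\C(=O)c2ccc(Br)cc2)S(=O)(=O)c2ccc(Br)cc2)c(F)c1` keeps the shared core and changes one group: 2-fluoro-4-methoxyphenyl in place of 4-bromo-3-hydroxyphenyl on a double-bonded chain carbon bound to a double-bonded chain carbon. Going by the values given here, the one measured step that bears on this swapped a group in that same place, a 2.0-fold higher number from compound 1 to compound 2 (0.30 log units; within the scatter). A single step is thin evidence, yet it gives no reason to expect a shift beyond the scatter in this assay. The expected change is a 1.7-fold lower number from compound 2 to compound 3 (0.22 log units; within the scatter). For compound 3 the estimated value is 30000 nM, with an expected range of 8000 nM to 100000 nM.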

Compound 3, concentration for 50% growth inhibition: 10000 nM
For compound 3 the middle estimate is 3.0-fold (0.48 log units) above the measured one; low and high end bracket the measured number.
By their numbers in this assay, from the lowest: compound 3; then compounds 1 and 2 (each within the scatter of the next).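

For the compounds shown here, at this place, on a double-bonded chain carbon bound to a double-bonded chain carbon, 2-fluoro-4-methoxyphenyl gives the only steps beyond the scatter in this assay: a 5.0-fold lower number from compound 2 to compound 3 (0.70 log units; beyond the scatter) and a 2.5-fold lower number from compound 1 to compound 3 (0.40 log units; beyond the scatter). The position can therefore respond to a change of group, which the earlier pair did not show. Nothing available here explains this shift.

From the compounds shown here alone, the fluorine and the methoxy group enter together, so their separate shares remain unknown. Going by these compounds, how an amine or a longer chain would read at this place also remains open.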